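Methoxy on compound 1: cytotoxicity notes

The compounds below may be only part of what the source reports. "The series", "measured", "known", "first", "only" and "open" are said of these compounds alone.

In an ADME assay on Vero cells (Chlorocebus sabaeus) for cytotoxicity, with a stated time of 72 h (on this read-out lower numbers stand for stronger inhibition and higher numbers for weaker inhibition), compound 1 `CCOC(=O)c1cc(/C=C\c2ccnc3ccccc23)on1` gives > 128000 nM, which is a limit and not a number. Compound 2 `CCOC(=O)c1cc(/C=C/c2ccnc3ccccc23)on1` gives > 128000 nM, also a limit. Compound 3 `CCOC(=O)c1cc(/C=C\c2ccc3ncccc3c2)on1` gives > 128000 nM, again a limit. The series therefore shows (the limit of > 128000 nM in this assay, at which 3 of the 3 values shown sit), and the standing of compound 1 among these compounds cannot be ranked.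

Compound 4 `CCOC(=O)c1cc(/C=C\c2ccnc3ccc(OC)cc23)on1` has methoxy in place of hydrogen on an aromatic carbon of the core of compound 1: methoxy in place of hydrogen on an aromatic carbon. Going by the values given here, the only measured step is a step that the two limits leave unreadable from compound 1 to compound 2. It gives no size, and it concerns the fact that compounds 1 and 2 differ only in the configuration as drawn rather than a new group. Among the compounds with values here, no measured step tests methoxy, so the data support no direction for this change.

The expected step, an at least 1.1-fold lower number from compound 1 to compound 4 (0.06 log units; that floor lies within the scatter), is estimated to stay within the usual scatter, and a reading at the same limit in this assay is the likeliest outcome. For compound 4 the estimate is 110000 nM, with an expected range of 45000 nM to 128000 nM.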

Compound 4, half-maximal inhibitory concentration: > 128000 nM
Compound 4 ended at the assay's limit; the forecaster's own chance of this, stated with the estimate: 70%; middle value at least 1.1-fold (0.06 log units) from the limit.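

Compound 4 gives > 128000 nM, a limit and not a number; compound 1 also sits at a limit, so the step between them cannot be read. The compounds shown leave open whether methoxy in place of hydrogen on an aromatic carbon changes cytotoxicity in either direction, with all readings at one ceiling: the limit of > 128000 nM in this assay, at which 4 of the 4 values shown sit.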